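Sulfonamide nitrogen substituents on the shared aryl-alkyne acid core

This account rests on a few compounds, and the source may have more. Where it says the series, first, only, none or still open, it means among the compounds named here.

For the measured compounds named here, compound 3 `Cc1ccc(S(=O)(=O)N(C)C)cc1C#Cc1cc(Cl)ccc1OCC(=O)O` gives 5 nM in an assay on CHO cells for displacement of a labelled ligand from prostaglandin D2 receptor 2 (Homo sapiens), read by scintillation counting (a higher number here means a weaker inhibitor, a lower number a stronger inhibitor), and stands second highest of the three numbers so far. Compound 2 `COCCNS(=O)(=O)c1ccc(C)c(C#Cc2cc(Cl)ccc2OCC(=O)O)c1` gives 3.6 nM in this assay, and a 1.4-fold higher number from compound 2 to compound 3 (0.14 log units; within the scatter). Compound 1 `Cc1ccc(S(=O)(=O)CCO)cc1C#Cc1cc(Cl)ccc1OCC(=O)O` gives 19 nM in this assay; a 3.8-fold lower number from compound 1 to compound 3 (0.58 log units; beyond the scatter), and a 5.3-fold lower number from compound 1 to compound 2 (0.72 log units; beyond the scatter). Compound 4 `Cc1ccc(S(=O)(=O)N(C)CCN(C)C)cc1C#Cc1cc(Cl)ccc1OCC(=O)O` carries (dimethylamino)methyl in place of hydrogen on a saturated chain carbon bound to a sulfonamide nitrogen. Going by the values given here, the measured steps that bear on it are the exchanges on the sulfonyl sulfur; the only one that swaps one amino group for another, a 1.4-fold higher number from compound 2 to compound 3 (0.14 log units; within the scatter), lies within the scatter, so for compound 4 no step beyond the scatter is expected in this assay. Compound 4 is estimated at 5 nM, with a range from 2 nM to 15 nM. The expected step is no change at the digits printed from compound 3 to compound 4 (within the scatter).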

Compound 4, inhibition constant: 369 nM
Compound 4: middle estimate off by 74-fold (1.87 log units), on the low side, outside the stated range (above it).
By their numbers in this assay, from the lowest: compounds 2 and 3 (each within the scatter of the next); then compound 1; then compound 4.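

In this assay, the substituents on the sulfonamide nitrogen are not interchangeable, as the earlier exchanges among amino groups might suggest: (dimethylamino)methyl in place of hydrogen on a saturated chain carbon bound to a sulfonamide nitrogen gives a 74-fold higher number from compound 3 to compound 4 (1.87 log units; beyond the scatter). The other comparisons agree, with a 100-fold higher number from compound 2 to compound 4 (2.01 log units; beyond the scatter) and a 19-fold higher number from compound 1 to compound 4 (1.29 log units; beyond the scatter), so compound 4 stands apart from all three earlier compounds. Nothing available here explains this step.

On these data alone, whether the step belongs to the amine itself or to the longer chain remains open. A methoxy group or a carboxylic acid in place of the dimethylamino group of compound 4 would separate the two.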